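The source may report more compounds than this note shows. Statements on the series, on what has been measured and on what is new or still open speak of the compounds shown alone.

Measured in a toxicity assay on MRC5 cells (Homo sapiens) for inhibition, read by MTT assay, with a stated time of 72 h; a lower number here means a stronger inhibitor, a higher number a weaker inhibitor:

Compound 1 `CCCCCCCCCCCCSCCc1ccc(OCc2ccc(OC)cc2)c(OCc2ccc(OC)cc2)c1`: > 50000 nM
Compound 2 `CCCCCCCCCCCCCC(=O)OCCc1ccc(O)c(O)c1`: > 50000 nM

Neither entry is a true number. In this assay compound 1 gives > 50000 nM, which is a limit of the assay. Compound 2 gives > 50000 nM, and this too is a limit and not a measured value. So compound 2 stands with compound 1 at the same reading: the limit of > 50000 nM in this assay, at which 2 of the 2 values shown sit.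

Compound 3 `CCCCCCCC(=O)OCCc1ccc(O)c(O)c1` has not yet been measured. It differs from compound 2 in one place: hydrogen in place of hexyl on a saturated chain carbon, seven bonds along the chain from a carbonyl carbon. In words, hydrogen stands in place of hexyl on a saturated chain carbon, seven bonds along the chain from a carbonyl carbon.

Going by the values given here, no measured pair of compounds shows what a change of this kind does in this assay. The expectation therefore rests on compound 2 and its limit of > 50000 nM. No step beyond the usual scatter is expected, in either direction, and compound 3 may well report as a limit too. The expected move is a number no higher from compound 2 to compound 3 (the limit leaves the size open). For compound 3 the estimated value is 50000 nM, with an expected range from 20000 nM to 100000 nM.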

Compound 3, half-maximal inhibitory concentration: 104000 nM
Beside the measured number, compound 3's estimate is 2.1-fold (0.32 log units) below it; the measured number lies above the stated range.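

No step can be read from compound 2 to compound 3 in this assay, because compound 2 reports only a limit and not a measured number: the limit of > 50000 nM in this assay, at which 2 of the 3 values shown sit.

The compounds shown leave open whether hydrogen in place of hexyl on this chain changes the reading in this assay at all, and by how much.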